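Ester variation on the shared core: dimethoxyphenyl in place of phenyl

The compounds below may be only part of what the source reports. "The series", "measured", "known", "first", "only" and "open" are said of these compounds alone.

Measured so far:
- compound 1 `COc1cc(C2Oc3cc([C@H]4Oc5cc(O)cc(O)c5C(=O)[C@@H]4O)ccc3OC2COC(=O)c2ccccc2)ccc1O` — 105000 nM
- compound 2 `COc1cc(C2Oc3cc([C@H]4Oc5cc(O)cc(O)c5C(=O)[C@@H]4O)ccc3OC2COC(=O)/C=C/c2ccc(Cl)cc2)ccc1O` — 87900 nM

Going by the values given here, in a functional assay, read by spectrophotometry, with a stated time of 30 min (on this read-out lower numbers stand for an effect already at smaller amounts and higher numbers for an effect only at larger amounts of compound), compound 1 gives 105000 nM, the highest of the two numbers; the only neighbour is compound 2, and a 1.2-fold lower number from compound 1 to compound 2 (0.08 log units; within the scatter).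

Compound 3 `COc1cc(C2Oc3cc([C@H]4Oc5cc(O)cc(O)c5C(=O)[C@@H]4O)ccc3OC2COC(=O)c2ccc(OC)c(OC)c2)ccc1O` is not yet measured. It differs from compound 1 by 3,4-dimethoxyphenyl in place of phenyl on a carbonyl carbon. Among the compounds with values here, no measured step touches a substituted phenyl on this carbonyl carbon; the one step known, from compound 1 to compound 2, changes the same position and stays within the scatter. For compound 3 the step of a 1.1-fold lower number from compound 1 to compound 3 (0.02 log units; within the scatter) is therefore expected to be small as well. Compound 3 is estimated at 100000 nM, in the range 40000 nM to 250000 nM.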

Compound 3, half-maximal effective concentration: 77000 nM
Compound 3: middle estimate off by 1.3-fold (0.11 log units), on the high side, and the stated range covers the measured number.
By their numbers in this assay, from the lowest: compounds 3, 2 and 1 (each within the scatter of the next).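

In this assay a substituted phenyl on this carbonyl carbon is now covered: 3,4-dimethoxyphenyl in place of phenyl gives a 1.4-fold lower number from compound 1 to compound 3 (0.13 log units; within the scatter) and stays level with the parent. Against the other ester, the change gives a 1.1-fold lower number from compound 2 to compound 3 (0.06 log units; within the scatter) and so the three groups tested here cannot be told apart, although 3,4-dimethoxyphenyl brings hydrogen-bond acceptors that phenyl lacks. Nothing at hand explains this flat reading.

From the compounds shown here alone, whether an amine or a carboxylic acid on the phenyl ring would move the number beyond the scatter remains open. So does the effect of an amide in place of the ester on the shared core.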